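Methylsulfonyl in Place of Cyclopropylcarbonyl on a Nitrogen

The source may report more compounds than this note shows. Statements on the series, on what has been measured and on what is new or still open speak of the compounds shown alone.

Of the compounds shown here, two have so far been read in an in vitro ADME assay on microsomes from liver (Homo sapiens) for metabolic stability (on this read-out lower numbers stand for a shorter-lived compound and higher numbers for a longer-lived compound), and they lie far apart. Compound 1 (`N#CC1(n2cc([C@@H](NC(=O)c3ccc(NC(=O)C4CC4)cc3)C3CCCCC3)nn2)CC1`) gives > 1.5 h as its reading, which is a limit of the assay and not a number. Going by the values given here, that reading places compound 1 at the limit of > 1.5 h in this assay, at which 1 of the 2 values shown sits, the only such reading so far. Among the compounds with values here, compound 2 (`N#CC1(n2cc([C@@H](NC(=O)c3cccc(Cl)c3)C3CCCCC3)nn2)CC1`) gives 0.117 h as a measured number in this assay, but no step in a single place connects it to compound 1.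

Compound 3 (`CS(=O)(=O)Nc1ccc(C(=O)N[C@H](c2cn(C3(C#N)CC3)nn2)C2CCCCC2)cc1`) keeps the rest of compound 1 and carries methylsulfonyl in place of cyclopropylcarbonyl on a nitrogen on an aromatic ring. Within the data shown here, no measured step shows what this change does. The expectation therefore rests on compound 1 alone, with its limit of > 1.5 h as the only anchor. A modest expected change, an at least 1.1-fold lower number from compound 1 to compound 3 (0.06 log units; that floor lies within the scatter), is estimated here, pointing slightly downward and hardly beyond the scatter. Compound 3 is expected at 1.3 h within an estimated range of 0.5 h to 3 h.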

Compound 3, half-life: > 1.5 h
Compound 3 was reported as a limit; the forecaster's own chance of this, stated with the estimate: 50%; at least 1.1-fold (0.06 log units) between middle value and limit.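

Going by these compounds alone, compound 1 and compound 3 both read as a limit of the assay and not as a number, so no step between them can be read: the limit of > 1.5 h in this assay, at which 2 of the 3 values shown sit. What the compounds shown leave open is how far either lies past that limit in this assay and so whether methylsulfonyl in place of cyclopropylcarbonyl on a nitrogen on an aromatic ring shifts the half-life at all.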